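The source may report more compounds than this note shows. Statements on the series, on what has been measured and on what is new or still open speak of the compounds shown alone.

Of the compounds shown here, three have been measured so far. Compound 1 `COc1ccc2c(c1)O[C@H](c1ccc(O)cc1)CC2` has a different core from the other two. Among the measured compounds shown here, in a functional assay on A549 cells (Homo sapiens) for cytotoxicity, read by MTT assay, with a stated time of 72 h (on this read-out lower numbers stand for stronger inhibition and higher numbers for weaker inhibition), compound 1 gives only a limit of the assay, > 100000 nM, the single value at the limit of > 100000 nM in this assay, at which 1 of the 3 values shown sits.

Compound 2 `COc1ccc(CCC(=O)c2ccc(O)cc2)c(OC)c1` and compound 3 `COc1ccc(CCC(=O)c2ccc(O)cc2)c(O)c1` share an open-chain core carrying a carbonyl. In this assay compound 2 gives 89500 nM, while compound 3 gives 12000 nM. The step of a 7.5-fold lower number from compound 2 to compound 3 (0.87 log units; beyond the scatter) shows that hydrogen in place of methyl on an oxygen on an aromatic ring lowered the number by a modest but real amount. Compound 3 therefore stands lowest of the two numbers in this assay, with compound 2 as its nearest neighbour.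

Compound 4 `O=C(CCc1ccc(O)cc1O)c1ccc(O)cc1` has not yet been measured. It differs from compound 3 as hydrogen in place of methyl on an oxygen on an aromatic ring: the remaining methoxy becomes hydroxy. For the measured compounds named here, only one measured step bears on this change, a 7.5-fold lower number from compound 2 to compound 3 (0.87 log units; beyond the scatter), which made the same replacement on the same core. Repeating it is expected to lower the number again, though a second such change need not be as large as the first. In this assay compound 4 is expected to give about 5000 nM, within 1500 nM to 15000 nM. The expected step of a 2.4-fold lower number from compound 3 to compound 4 (0.38 log units; beyond the scatter) is thus estimated to be smaller than a 7.5-fold lower number from compound 2 to compound 3 (0.87 log units; beyond the scatter).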

Compound 4, half-maximal inhibitory concentration: > 100000 nM
Compound 4 gave a limit, no number (the forecaster's own chance of this, stated with the estimate: 5%); middle value at least 20-fold (1.30 log units) away from the limit.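

In this assay, the change that had lowered the number from compound 2 to compound 3, a 7.5-fold lower number from compound 2 to compound 3 (0.87 log units; beyond the scatter), reverses when it is made at the remaining methoxy: an at least 8.3-fold higher number from compound 3 to compound 4 (0.92 log units; beyond the scatter). Hydrogen in place of methyl on an oxygen on an aromatic ring therefore has no single direction on this core, and the outcome depends on which of the two methoxy groups is changed, something the first pair alone could not show. Compound 4 gives a limit of the assay and not a number, so only the lower bound of this rise is known, and this limit now recurs among the compounds shown: the limit of > 100000 nM in this assay, at which 2 of the 4 values shown sit.

The compounds shown leave open whether this place needs the methyl itself or would accept another group on the oxygen, such as an ethoxy or a longer alkoxy chain. They also leave open what an amine or a fluorine in place of that oxygen would give in this assay.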